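A few compounds are considered here, and "the series" means these few. Any claim that something is new, unique, unknown or untested is made for them only; others in the source may bear on it.

Within the data shown here, in a functional assay on MOLT-4 cells (Homo sapiens) for antiproliferative activity, read by MTT assay, with a stated time of 48 h (on this read-out lower numbers stand for stronger inhibition and higher numbers for weaker inhibition), compound 2 `O=C(CCCCCCn1cc(Nc2ncc(Cl)c(Nc3ccccc3Cl)n2)cn1)NO` gives 510 nM, the higher of the two numbers so far, while compound 1 `O=C(CCCCCCn1cc(Nc2ncc(Cl)c(Nc3ccc(F)cc3)n2)cn1)NO` gives 220 nM. Compound 3 `O=C(CCCCCCn1cc(Nc2ncc(Cl)c(Nc3ccc(Cl)cc3)n2)cn1)NO` differs from compound 2 by one change: 4-chlorophenyl in place of 2-chlorophenyl on a nitrogen on an aromatic ring. Among the measured compounds shown here, the only measured step that bears on this change is modest, a 2.3-fold higher number from compound 1 to compound 2 (0.37 log units; beyond the scatter), and it replaces 4-fluorophenyl with 2-chlorophenyl, so it is only a partial guide. A similarly modest move to a lower number is therefore expected, an estimated 1.9-fold lower number from compound 2 to compound 3 (0.28 log units; within the scatter). For compound 3 the expected value is 270 nM, with an estimated range of 120 nM to 600 nM.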

Compound 3, half-maximal inhibitory concentration: 120 nM
Compound 3: the middle estimate sits 2.3-fold (0.35 log units) above what was measured; the range from low to high includes it.
By their numbers in this assay, from the lowest: compounds 3 and 1 (each within the scatter of the next); then compound 2.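

In this assay, where the chlorine sits on the phenyl group matters: with the same atoms joined differently, 4-chlorophenyl in place of 2-chlorophenyl gives a 4.3-fold lower number from compound 2 to compound 3 (0.63 log units; beyond the scatter) on the nitrogen-bound aromatic ring. Chloro in place of fluoro on the aromatic carbon, by contrast, gives a 1.8-fold lower number from compound 1 to compound 3 (0.26 log units; within the scatter), so compound 1 and compound 3 are not separated here. No measurement available here accounts for the effect of moving the chlorine. Going by these compounds, whether a methoxy group, an amine or a nitrile in place of that chloro would keep this level remains open. So does the effect of a longer chain in place of the one shared by all three compounds.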